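The source may report more compounds than this note shows. Statements on the series, on what has been measured and on what is new or still open speak of the compounds shown alone.

Values so far in a functional assay with Homo sapiens as the target; on this read-out lower numbers stand for stronger inhibition and higher numbers for weaker inhibition:
- compound 1 `CC(C)[C@H](NC(=O)COc1cccc2ccccc12)C(=O)N[C@@H](CC(=O)O)C(=O)COC(=O)c1c(Cl)cccc1Cl` gives 11500 nM
- compound 2 `CC(C)[C@H](NC(=O)COc1cccc2ccccc12)C(=O)N[C@@H](CC(=O)O)C(=O)COc1ccc(C(F)(F)F)cc1` gives 12300 nM
- compound 3 `CC(C)[C@H](NC(=O)COc1cccc2ccccc12)C(=O)N[C@@H](CC(=O)O)C(=O)COc1ccccc1F` gives 15700 nM

Compound 3 stands level with the other two within the scatter, with a 1.4-fold higher number from compound 1 to compound 3 (0.14 log units; within the scatter) and a 1.3-fold higher number from compound 2 to compound 3 (0.11 log units; within the scatter) as its gaps. Next comes compound 4 `CC(C)[C@H](NC(=O)COc1cccc2ccccc12)C(=O)N[C@@H](CC(=O)O)C(=O)COc1ccc(F)c(F)c1F`, with 2,3,4-trifluorophenyl in place of 2-fluorophenyl on an oxygen on a saturated carbon, as 2,3,4-trifluorophenyl in place of 2-fluorophenyl on an oxygen on a saturated carbon counts. Three measured steps at this oxygen bear on it, these two and a 1.1-fold higher number from compound 1 to compound 2 (0.03 log units; within the scatter) as well, all within the scatter. Going by the values given here, no measured step isolates added fluorine. No step beyond the scatter is therefore expected in this assay here. The expected move is a 1.2-fold lower number from compound 3 to compound 4 (0.08 log units; within the scatter) and no more. Compound 4 is estimated at 13000 nM with an expected range of 7000 nM to 24000 nM on this read-out.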

Compound 4, half-maximal inhibitory concentration: 20600 nM
Compound 4: middle estimate off by 1.6-fold (0.20 log units), on the low side; the measured number falls inside the stated range.
By their numbers in this assay, from the lowest: compounds 1, 2, 3 and 4 (each within the scatter of the next).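

In this assay, 2,3,4-trifluorophenyl in place of 2-fluorophenyl on this oxygen stays within the scatter (a 1.3-fold higher number from compound 3 to compound 4 (0.12 log units; within the scatter)). The same holds against the 4-(trifluoromethyl)phenyl group (a 1.7-fold higher number from compound 2 to compound 4 (0.22 log units; within the scatter)) and the (2,6-dichlorophenyl)carbonyl group (a 1.8-fold higher number from compound 1 to compound 4 (0.25 log units; within the scatter)), so all four groups at this oxygen now read level. Nothing at hand accounts for this flat reading.

Going by these compounds, whether an amine or a carboxylic acid on the phenyl ring, or a longer chain on this oxygen, would move the number beyond the scatter stays open. So does the effect of changes elsewhere on the shared core.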